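Phenylsulfonyl to Hydrogen on an Aromatic Nitrogen, Twice

The source may hold more compounds than are shown below. What is called first, only, known or untested is meant among the compounds shown, and "the series" means these compounds.

Measured compounds:
compound 1, `O=S(=O)(c1ccccc1)n1ccc2cc(/C=C\c3ccc4ccccc4c3)ccc21`: > 5000 nM
compound 2, `C(=C\c1ccc2[nH]ccc2c1)\c1ccc2ccccc2c1`: > 5000 nM
compound 3, `COc1cc(/C=C/c2ccc3c(ccn3S(=O)(=O)c3ccccc3)c2)cc(OC)c1OC`: > 5000 nM

The study concerns three measured compounds and one that is still to be measured, all read in a functional assay on A549 cells (Homo sapiens) for inhibition; on this read-out higher numbers stand for weaker inhibition and lower numbers for stronger inhibition. In this assay compound 1 gives > 5000 nM, which is a limit of the assay and not a number. Compound 2 gives > 5000 nM, again a limit. Compound 3 likewise gives > 5000 nM, a limit as well. Compound 1 and compound 2 differ in one place only: hydrogen in place of phenylsulfonyl on an aromatic nitrogen. The step between them, a step that the two limits leave unreadable from compound 1 to compound 2, cannot be read, since both values are limits. The same kind of change is made from compound 3 to compound 4, `COc1cc(/C=C/c2ccc3[nH]ccc3c2)cc(OC)c1OC`: hydrogen in place of phenylsulfonyl on an aromatic nitrogen. The two places are described in the same words. How the core of compound 1 and the core of compound 3 differ is not broken down here. What the measured compounds share is the limit of > 5000 nM in this assay, at which 3 of the 3 values shown sit, and on that rests the expectation for compound 4: the step that the limit leaves unreadable from compound 3 to compound 4 is an estimate only, since the measured step of the same kind gave no readable size. Compound 4 is therefore expected to sit near 8000 nM, between 2000 nM and 30000 nM, most likely reported again as a limit.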

Compound 4, half-maximal inhibitory concentration: 470 nM
Estimate against measurement, compound 4: 17-fold (1.23 log units) above, and the stated range ends above it.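

In this assay, hydrogen in place of phenylsulfonyl on an aromatic nitrogen gives an at least 10-fold lower number from compound 3 to compound 4 (1.02 log units; beyond the scatter), so on the core of compound 3 this single change turns a limit of the assay into a measured number. On the core of compound 1 the same change cannot be read, since compound 1 and compound 2 both stand at limits of the assay, and compound 2 goes against any rule that removing phenylsulfonyl always yields a measured number. The result therefore shows what the change does on one core only; it does not show that the step carries from one core to another, and most of the series still stands at a single limit: the limit of > 5000 nM in this assay, at which 3 of the 4 values shown sit.

What the compounds shown leave open is whether the hydrogen on the aromatic nitrogen is itself required, or whether a methyl or an acetyl group in that place would give a value like that of compound 4. Also open, going by these compounds, is the size of the step on the core of compound 1, which stays unknown as long as both of its compounds stand at limits.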